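Changing the Aryl Ring on the Chain of Compound 2

The source may report more compounds than this note shows. Statements on the series, on what has been measured and on what is new or still open speak of the compounds shown alone.

In a functional assay on K562 cells (Homo sapiens) for antiproliferative activity, read by MTT assay, with a stated time of 24 h (on this read-out higher numbers stand for weaker inhibition and lower numbers for stronger inhibition), compound 2 `COc1ccc(C(=O)/C=C/c2ccccn2)c2c1C=CC(C)(C)O2` gives 5400 nM, and compound 1 `COc1ccc(C(=O)/C=C/c2ccc([N+](=O)[O-])cc2)c2c1C=CC(C)(C)O2` gives 7770 nM, the two numbers standing within the scatter of each other. Compound 3 `COc1ccc(C(=O)/C=C/c2ccc(Cl)c(Cl)c2)c2c1C=CC(C)(C)O2` differs from compound 2 by 3,4-dichlorophenyl in place of pyridin-2-yl on a double-bonded chain carbon bound to a double-bonded chain carbon. For the measured compounds named here, the only measured step of this kind, an exchange of the ring on the same chain carbon, is a 1.4-fold lower number from compound 1 to compound 2 (0.16 log units; within the scatter), and it stayed within the scatter. For compound 3 a step of a 1.1-fold lower number from compound 2 to compound 3 (0.03 log units; within the scatter) is therefore expected, nothing beyond the scatter. Compound 3 is estimated at 5000 nM, with a range from 1500 nM to 16000 nM.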

Compound 3, half-maximal inhibitory concentration: 9030 nM
Beside the measured number, compound 3's estimate is 1.8-fold (0.26 log units) below it, and the stated range covers the measured number.
By their numbers in this assay, from the lowest: compounds 2, 1 and 3 (each within the scatter of the next).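

In this assay, 3,4-dichlorophenyl on the double-bonded chain carbon gives a 1.7-fold higher number from compound 2 to compound 3 (0.22 log units; within the scatter) and a 1.2-fold higher number from compound 1 to compound 3 (0.07 log units; within the scatter). With a ring of carbon only that carries two chlorines, the three rings now shown at this place still stand within the scatter of one another, so swapping among these rings separates none of the compounds. No measurement offered here explains this result. Open, as far as these compounds go, is whether a ring bearing an amine or a carboxylic acid, or a saturated cyclohexyl ring, would give a step beyond the scatter at this place.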